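Demethylation on a benzofuran core against urate transporter 1

The source may report more compounds than this note shows. Statements on the series, on what has been measured and on what is new or still open speak of the compounds shown alone.

Of the compounds shown here, three from one series have been tested in an assay for inhibition of solute carrier family 22 member 12 (Homo sapiens), read by scintillation counting, with a stated time of 60 min, tested at 50 uM; a lower number here means less inhibition, a higher number more inhibition at the concentration tested (going by the name of the read-out). Compound 1 `CCc1cc2c(C(=O)c3ccc(OC)cc3)cc(OC)cc2o1` carries two methoxy groups, and in this assay compound 1 gives 1.5%. Compound 2 `CCc1cc2c(C(=O)c3ccc(O)cc3)cc(OC)cc2o1` differs from it in one place:

hydrogen in place of methyl on an oxygen on an aromatic ring

That change brings a number 60.9 percentage points higher from compound 1 to compound 2 (beyond the scatter). In this assay compound 2 gives 62.4%. Compound 3 `CCc1oc2ccc(OC)cc2c1C(=O)c1cc(Br)c(O)c(Br)c1` is built on a different pattern, with two bromine atoms flanking a hydroxy group on the benzoyl ring and a methoxy group on the other core; how its core differs from that of compound 1 is not broken down here. In this assay compound 3 gives 99.9%, the highest of the three numbers, and its distance to compound 2 as well as to compound 1 is in each case beyond the scatter.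

Compound 4 `CCc1oc2ccc(O)cc2c1C(=O)c1cc(Br)c(O)c(Br)c1` has not yet been measured. It differs from compound 3 in one place:

hydrogen in place of methyl on an oxygen on an aromatic ring

The change is the same one that was made from compound 1 to compound 2, and in that pair it produced the large upward step already described. Compound 3, however, already sits at the top of what this assay can report, so there is little room for a similar rise. The expectation is that compound 4 stays high, with a step of about a number 2.9 percentage points lower from compound 3 to compound 4 (within the scatter) from compound 3, resting on the value of compound 3 at 99.9% and on the direction of the step from compound 1 to compound 2. Compound 4 is therefore estimated at 97%, within a range from 82% to 100%.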

Compound 4, a percentage reported as inhibition, at one concentration (the size of the read-out at that concentration, not a potency): 99.9%
For compound 4 the middle estimate is 2.9 percentage points below the measured one, within the range that was stated.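

In this assay the change from methoxy to hydroxy gives no change at the digits printed from compound 3 to compound 4 (within the scatter), so the rise seen on the core of compound 1 does not appear on the core of compound 3. Set beside the earlier step, the same change therefore does not carry over in size from one core to the other in this series: the same change on two cores in this assay, a number 60.9 percentage points higher (beyond the scatter) from compound 1 to compound 2 and no change at the digits printed (within the scatter) from compound 3 to compound 4, 60.9 percentage points apart, beyond the scatter of two such steps

This does not show that the hydroxy group is without consequence on the second core, since compound 3 gives 99.9% and compound 4 gives 99.9%, both at the top of what a percentage of inhibition can report at a single concentration, and a difference in potency could lie hidden there while the two pairs, each a single case, also replace different methoxy groups.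

Still open, going by these compounds, is whether compound 3 and compound 4 would separate at a lower concentration, and whether the change would matter on this core without the two bromine atoms. The compounds shown also leave open what an amine or a carboxylic acid would give in place of the hydroxy group of compound 4, and what a chain longer than ethyl would give.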